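Compound 3: swapping formyl for 2-cyanoethenyl

This account rests on a few compounds, and the source may have more. Where it says the series, first, only, none or still open, it means among the compounds named here.

Compound 1 `C=C[C@@](C)(/C=C/c1ccc(O)c(/C=C/C#N)c1)CCC=C(C)C`: > 49000 nM (a limit)
Compound 2 `COc1ccc(/C=C/[C@@](C)(/C=C/c2ccc(O)c(C=O)c2)CCC=C(C)C)cc1`: > 49000 nM (a limit)

In a functional assay on Jurkat cells (Homo sapiens) for cytotoxicity, with a stated time of 72 h (a higher number here means that more compound is needed for the effect, a lower number that less compound is needed), compound 2 gives > 49000 nM, which is a limit and not a number. Among the measured compounds shown here, the series so far shows only (the limit of > 49000 nM in this assay, at which 2 of the 2 values shown sit).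

Compound 3 `COc1ccc(/C=C/[C@@](C)(/C=C/c2ccc(O)c(/C=C/C#N)c2)CCC=C(C)C)cc1` has 2-cyanoethenyl in place of formyl on an aromatic carbon, ortho to a hydroxy group: 2-cyanoethenyl in place of formyl on an aromatic carbon. Compound 1 also carries 2-cyanoethenyl and gives > 49000 nM, again a limit. No measured step sizes this change, so only a small move toward lower numbers is expected: an at least 1.2-fold lower number from compound 2 to compound 3 (0.08 log units; that floor lies within the scatter). The estimate for compound 3 is 40000 nM, with an expected range of 15000 nM to 49000 nM.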

Compound 3, half-maximal effective concentration: > 49000 nM
Compound 3 was reported as a limit (the forecaster's own chance of this, stated with the estimate: 60%); at least 1.2-fold (0.08 log units) between middle value and limit.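

No step can be read among compound 1, compound 2 and compound 3 in this assay; all three sit at one limit: the limit of > 49000 nM in this assay, at which 3 of the 3 values shown sit.

Going by these compounds, whether 2-cyanoethenyl in place of formyl changes the read-out at all, and by how much, stays open.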